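The source may hold more compounds than are shown below. What is called first, only, known or untested is meant among the compounds shown, and "the series" means these compounds.

Measured so far in a functional assay on HEL cells (Homo sapiens); on this read-out higher numbers stand for lower toxicity in this test and lower numbers for higher toxicity in this test:
compound 1 `O=C1c2ccccc2N(Cc2ccc(Cl)cc2)S(=O)(=O)N1Cc1ccccc1` — > 5000 nM
compound 2 `O=C1c2ccccc2N(Cc2ccc(Cl)cc2)S(=O)(=O)N1Cc1ccc(Cl)cc1` — > 50000 nM
compound 3 `O=S1(=O)N=C(OCc2ccccc2)c2ccccc2N1Cc1ccc(Cl)c(Cl)c1` — 200000 nM

Compound 1 stands only as a limit of this assay, > 5000 nM, and one further value in the set is also a limit. Compound 4 `O=C1c2ccccc2N(Cc2ccc(Cl)c(Cl)c2)S(=O)(=O)N1Cc1ccccc1` differs from compound 1 by chloro in place of hydrogen on an aromatic carbon.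

Among the measured compounds shown here, the only single-place step measured, a step that the two limits leave unreadable from compound 1 to compound 2, cannot be read because both ends sit at limits, the limit of > 5000 nM in this assay, at which 1 of the 3 values shown sits, and (the limit of > 50000 nM in this assay, at which 1 of the 3 values shown sits). For the measured compounds named here, compound 3, which carries a 3,4-dichlorobenzyl group on a related core, gives 200000 nM, a number rather than a limit; no step to compound 4 is computed for that pair, so it serves only as a pointer that a dichlorobenzyl compound of this series can sit far up the scale.

Compound 4 is therefore expected to show low toxicity in this assay, most likely reported as a limit again, estimated at 50000 nM with a range of 5000 nM to 200000 nM. The expected step is a step that the limit leaves unreadable from compound 1 to compound 4, and its direction cannot be told from a limit start.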

Compound 4, minimum cytotoxic concentration: 200000 nM
Estimate against measurement, compound 4: 4.0-fold (0.60 log units) below, and the stated range covers the measured number.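

In this assay compound 4 gives 200000 nM. Among the compounds shown here, no step from compound 1 to compound 4 can be read, since compound 1 stands only as a limit: the limit of > 5000 nM in this assay, at which 1 of the 4 values shown sits. From the compounds shown here alone, the size and direction of the change from 4-chlorobenzyl to 3,4-dichlorobenzyl remain open.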